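A few compounds are considered here, and "the series" means these few. Any claim that something is new, unique, unknown or untested is made for them only; others in the source may bear on it.

Measured so far in an ADME assay on microsomes from liver (Homo sapiens) for metabolic stability, read by LC-MS, with a stated time of 10 min; a lower number here means that less of the compound is left, a higher number that more of the compound is left:
compound 1 `C[C@@H]1CN(c2cccc3c2C[C@H](CN(C)[C@H]2CCCc4cccnc42)NC3)C[C@H](C)N1` gives 100%
compound 2 `CC(C)N(C[C@H]1Cc2c(cccc2N2CCNCC2)CN1)[C@H]1CCCc2cccnc21` gives 75%

Compound 1 stands highest of these two numbers; its nearest neighbour is compound 2, whose value is lower by a margin beyond the usual scatter. Compound 3 `CN(C[C@H]1Cc2c(cccc2N2C[C@@H]3C[C@H]2CN3)CN1)[C@H]1CCCc2cccnc21` is not yet measured. It differs from compound 1 in one place: a group of 7 heavy atoms (5 carbon, 2 nitrogen; 2 five-membered non-aromatic rings with 1 hetero atom each) in place of a group of 8 heavy atoms (6 carbon, 2 nitrogen; one six-membered non-aromatic ring with 2 hetero atoms), on an aromatic carbon. Within the data shown here, no step between measured compounds isolates this change, so a prediction rests on little. Because compound 1 gives 100% and the change is small, a modest move downward, or none beyond the scatter, is expected: a number 12 percentage points lower from compound 1 to compound 3 (beyond the scatter). Compound 3 is therefore estimated at 88%, within 65% to 100%.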

Compound 3, percent of the compound remaining: 100%
Estimate against measurement, compound 3: 12 percentage points below, within the range that was stated.
By their numbers in this assay, from the lowest: compound 2; then compounds 1 and 3 (each within the scatter of the next).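

In this assay, replacing the 3,5-dimethylpiperazin-1-yl group on this aromatic carbon with the group of 2 five-membered non-aromatic rings gives no change at the digits printed from compound 1 to compound 3 (within the scatter). The earlier compounds shown here offered no step at this position, and this one shows that the position tolerates this change of ring system in this read-out. Nothing measured here gives a reason for this result. Still open, as far as these compounds go, is whether a morpholine or an open-chain dimethylamino group on the same carbon would leave the number unchanged too. Also open, from the compounds shown here alone, is whether this tolerance holds with a different group on the amine nitrogen of the side chain.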